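A few compounds are considered here, and "the series" means these few. Any claim that something is new, unique, unknown or untested is made for them only; others in the source may bear on it.

For the measured compounds named here, compound 1, with the structure `COc1ccc2c(c1)c(-c1cc(C(F)(F)F)ccn1)cn2S(=O)(=O)c1ccc(C)cc1`, is one of two compounds measured in a functional assay on A549 cells (Homo sapiens) for inhibition, tested at 10 uM; on this read-out lower numbers stand for a weaker effect and higher numbers for a stronger effect at the one concentration tested. In this assay compound 1 gives 9.9%, the lower of the two numbers. The other compound, compound 2, has the structure `COc1ccc2c(-c3cc(C(F)(F)F)cc(-c4cn(S(=O)(=O)c5ccc(C)cc5)c5cc(OC)ccc45)n3)cn(S(=O)(=O)c3ccc(C)cc3)c2c1` and gives 28.8% in this assay, a number that lies beyond the usual scatter above that of compound 1. The two structures differ in more than one place, so their values are only compared side by side, and no single change can be drawn from them.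

Compound 3, with the structure `Cc1ccc(S(=O)(=O)n2cc(-c3cc(C(F)(F)F)ccn3)c3cc(OCc4ccccc4)ccc32)cc1`, has not yet been measured. It differs from compound 1 in one place: phenyl in place of hydrogen on a saturated chain carbon bound to an oxygen on an aromatic ring. Going by the values given here, no comparable step between measured compounds is available, so the direction of this change in this assay is open; a small step of either sign, within the scatter, seems the most likely outcome. On that basis compound 3 is expected to give about 14% in this assay, with a range from 0% to 35%. The expected step of a number 4.1 percentage points higher from compound 1 to compound 3 (within the scatter) is therefore estimated to be small.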

Compound 3, a percentage reported as inhibition, at one concentration (the size of the read-out at that concentration, not a potency): 9.9%
For compound 3 the middle estimate is 4.1 percentage points above the measured one, and the stated range covers the measured number.
By their numbers in this assay, from the lowest: compounds 1 and 3 (each within the scatter of the next); then compound 2.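

Swapping methoxy for benzyloxy gives the first single-place comparison at this position, and in this assay the step reads no change at the digits printed from compound 1 to compound 3 (within the scatter). Phenyl, with its 6 heavy atoms, can therefore be placed on this saturated chain carbon bound to an oxygen on an aromatic ring with no effect beyond the scatter on this read-out, at the one concentration tested. This is a single step in which both numbers are small, and nothing available explains the result.

Going by these compounds, whether another group in place of that phenyl, such as an amine, a carboxylic acid or a longer chain, would give a number beyond the scatter of compound 1 remains open. On these data alone, it is also open whether phenyl at this place would read the same way on compound 2, which carries two methoxy groups.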